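Trifluoromethyl for Isopropylsulfonyl on the Butyl Chain

This account rests on a few compounds, and the source may have more. Where it says the series, first, only, none or still open, it means among the compounds named here.

Compound 2 `CC(C)S(=O)(=O)CCCn1c(Cn2c(=O)n(C3CC3)c3ccncc32)nc2ccccc21` holds the only numerical result in an ADME assay on HEp-2 cells (Homo sapiens) for cytotoxicity; on this read-out lower numbers stand for higher toxicity in this test and higher numbers for lower toxicity in this test: compound 2 gives 49200 nM. Compound 1 `CC(C)S(=O)(=O)n1c(=O)n(Cc2nc3ccccc3n2CCCC#N)c2cnccc21` reached only a limit in this assay, > 228000 nM, and that is all its entry shows (the limit of > 228000 nM in this assay, at which 1 of the 2 values shown sits). Compound 3 `O=c1n(Cc2nc3ccccc3n2CCCC(F)(F)F)c2cnccc2n1C1CC1` differs from compound 2 by trifluoromethyl in place of isopropylsulfonyl on a saturated chain carbon, three bonds along the chain from an aromatic nitrogen. Going by the values given here, no measured step joins two numbers here, so only a modest shift toward lower toxicity in this assay is expected, and it may well stay within the scatter: the expected step is a 1.6-fold higher number from compound 2 to compound 3 (0.21 log units; within the scatter). Compound 3 is accordingly estimated at 80000 nM, within 25000 nM to 250000 nM.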

Compound 3, half-maximal cytotoxic concentration: 55700 nM
For compound 3 the middle estimate is 1.4-fold (0.16 log units) above the measured one, and the stated range covers the measured number.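

In this assay, going by these compounds alone, trifluoromethyl in place of isopropylsulfonyl gives a 1.1-fold higher number from compound 2 to compound 3 (0.05 log units; within the scatter), the first measured step at this position. On this read-out, the chain end therefore gave up the sulfonyl group and its two hydrogen-bond acceptors with the two numbers remaining within the scatter of each other. Nothing in the data shown accounts for this result. Going by these compounds, whether an amine, a carboxylic acid or a longer chain at this carbon would also stay within the scatter remains open.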